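From methoxy to chloro at the assay limit

The compounds below may be only part of what the source reports. "The series", "measured", "known", "first", "only" and "open" are said of these compounds alone.

In a functional assay on KYSE-410 cells (Homo sapiens) for antiproliferative activity, read by MTT assay, with a stated time of 72 h (on this read-out lower numbers stand for stronger inhibition and higher numbers for weaker inhibition), compound 1 (`O=C(Nc1ccc(Cl)cc1)c1cc(=O)[nH]c2cc(Br)ccc12`) gives > 20000 nM as a limit of the assay. Compound 2 (`O=C(Nc1ccccn1)c1cc(=O)[nH]c2cc(Br)ccc12`) gives 9800 nM as a measured number. Compound 3 (`COc1cccc(NC(=O)c2cc(=O)[nH]c3cc(Br)ccc23)c1`) gives > 20000 nM as a limit too. It thus stands at the limit of > 20000 nM in this assay, at which 2 of the 3 values shown sit, on these data. Compound 4 (`O=C(Nc1cccc(Cl)c1)c1cc(=O)[nH]c2cc(Br)ccc12`) has chloro in place of methoxy on an aromatic carbon. Among the compounds with values here, no measured step makes this exchange. Within the data shown here, the only measured step (an at least 2.0-fold lower number from compound 1 to compound 2 (0.30 log units; that floor lies within the scatter)) swaps 4-chlorophenyl for pyridin-2-yl and bears on it only loosely, its floor lying within the scatter. Compound 1, which also carries chloro, shows > 20000 nM as a limit, so no change beyond the scatter is expected. The expected step (a number no higher from compound 3 to compound 4 (the limit leaves the size open)) is therefore small. For compound 4 the estimated value in this assay is 20000 nM with 10000 nM and 40000 nM as the ends of the expected range.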

Compound 4, half-maximal inhibitory concentration: > 20000 nM
Compound 4 was reported as a limit (the forecaster's own chance of this, stated with the estimate: 70%); the middle value lies on the limit itself.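

Compound 4 is a limit in this assay, so chloro on this aromatic carbon yields no measured number, any more than methoxy did, and its steps from compound 3 and compound 1 cannot be read. The position now holds two groups at the same limit: the limit of > 20000 nM in this assay, at which 3 of the 4 values shown sit 3-Chlorophenyl in place of pyridin-2-yl gives an at least 2.0-fold higher number from compound 2 to compound 4 (0.30 log units; that floor lies within the scatter), so that floor does not separate the two amides. The compounds shown leave open whether any group on this aromatic carbon gives a measured number. On these data alone, an amine or a carboxylic acid there remains untested in this set.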